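The source may report more compounds than this note shows. Statements on the series, on what has been measured and on what is new or still open speak of the compounds shown alone.

Measured so far in a functional assay on BJAB cells (Homo sapiens) for antiproliferative activity, with a stated time of 4 days; on this read-out higher numbers stand for an effect only at larger amounts of compound and lower numbers for an effect already at smaller amounts:

Compound 1 `Cc1c(-c2cc(Cl)cc(Cl)c2)c(C(=O)O)nn1-c1nc(-c2cnn(C)c2)c(SC(C)C)s1`: "not active" (no number reported)
Compound 2 `Cc1cc(C)cc(-c2c(C)nn(-c3nc(-c4ccc(Cl)c(Cl)c4)c(SC(C)C)s3)c2C(=O)O)c1`: 2700 nM
Compound 3 `Cc1cc(Cl)cc(-c2c(C)nn(-c3nc(-c4ccc(Cl)c(Cl)c4)c(SC(C)C)s3)c2C(=O)O)c1`: 663 nM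

Among the two numbers, compound 3 has the lowest, and its nearest neighbour is compound 2, with a 4.1-fold lower number from compound 2 to compound 3 (0.61 log units; beyond the scatter); compound 1 is without a number. Compound 4 `Cc1nn(-c2nc(-c3ccc(Cl)c(Cl)c3)c(SC(C)C)s2)c(C(=O)O)c1-c1ccccc1[N+](=O)[O-]` differs from compound 3 by 2-nitrophenyl in place of 3-chloro-5-methylphenyl on an aromatic carbon. Among the compounds with values here, only one measured step touches this region of the molecule, the exchange between compound 2 and compound 3 with a 4.1-fold lower number from compound 2 to compound 3 (0.61 log units; beyond the scatter), and that step swapped a single substituent while the ring itself stayed. The step to compound 4 replaces the whole substituted phenyl group with a differently substituted one, so the measured step gives only a weak hint of the size to expect, and no hint of direction. Given that uncertainty, compound 4 is expected to land somewhat weaker, with a 4.5-fold higher number from compound 3 to compound 4 (0.66 log units; beyond the scatter), and the estimate for compound 4 in this assay is 3000 nM, within a range from 600 nM to 15000 nM.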

Compound 4, half-maximal effective concentration: 4700 nM
Compound 4: middle estimate off by 1.6-fold (0.19 log units), on the low side; the range from low to high includes it.
By their numbers in this assay, from the lowest: compound 3; then compounds 2 and 4 (each within the scatter of the next).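

In this assay, a phenyl group on this aromatic carbon can be exchanged for one with a different substitution pattern, and the value responds: 2-nitrophenyl in place of 3-chloro-5-methylphenyl gives a clear loss (a 7.1-fold higher number from compound 3 to compound 4 (0.85 log units; beyond the scatter)). Set against 3,5-dimethylphenyl, the same 2-nitrophenyl group gives no separable change (a 1.7-fold higher number from compound 2 to compound 4 (0.24 log units; within the scatter)), so among these three compounds only the 3-chloro-5-methylphenyl group of compound 3 stands apart. Nothing measured here explains this behaviour at the position.

On these data alone, it remains open whether the value of compound 4 depends on the nitro group itself, on where it sits on the phenyl ring, or on the loss of the chloro and methyl groups. A plain phenyl, a 3-nitrophenyl or a 2-aminophenyl group on this carbon would help separate these possibilities.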